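Chloro in Place of Methyl on the Phenylpiperazine Ring

This account rests on a few compounds, and the source may have more. Where it says the series, first, only, none or still open, it means among the compounds named here.

Two compounds share a core that carries a phenylpiperazine thiosemicarbazone. Compound 1 `Cc1ccc2c(c1)/C(=N/NC(=S)N1CCN(c3ccccc3)CC1)C(=O)N2` is measured in a functional assay on HCT-116 cells (Homo sapiens) for inhibition, read by MTT assay, with a stated time of 72 h (a lower number here means a stronger inhibitor, a higher number a weaker inhibitor), and gives 9480 nM, while compound 2 `Cc1ccccc1N1CCN(C(=S)N/N=C2\C(=O)Nc3ccc(Cl)cc32)CC1` gives 4910 nM in this assay; these two numbers lie within the scatter of each other, so neither stands apart. Compound 3 `O=C1Nc2ccc(Cl)cc2/C1=N/NC(=S)N1CCN(c2ccccc2Cl)CC1` differs from compound 2 in one place: chloro in place of methyl on an aromatic carbon, ortho to a large group. Among the measured compounds shown here, no measured pair shows what this swap does, so the expected step of a 1.0-fold lower number from compound 2 to compound 3 (0.01 log units; within the scatter) is none beyond the scatter. Compound 3 is therefore estimated at 4800 nM, with a range from 1800 nM to 13000 nM.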

Compound 3, half-maximal inhibitory concentration: 4910 nM
Estimate against measurement, compound 3: 1.0-fold (0.01 log units) below; low and high end bracket the measured number.
By their numbers in this assay, from the lowest: compounds 2, 3 and 1 (each within the scatter of the next).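

In this assay, putting chloro in place of methyl on an aromatic carbon, ortho to a large group, gives no change at the digits printed from compound 2 to compound 3 (within the scatter). Among the compounds shown here, this is the first direct reading of this swap, and at this position the 2-methylphenyl and 2-chlorophenyl compounds cannot be told apart. Nothing available explains this match. Still open, as far as these compounds go, is whether a methoxy group, an amine or a carboxylic acid at the same position would also leave the number within the scatter. A single pair also cannot show whether this swap would give the same result on another core.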